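Inverting the stereocentre of compound 2

This account rests on a few compounds, and the source may have more. Where it says the series, first, only, none or still open, it means among the compounds named here.

Measured compounds:
compound 1, `CCc1cccc(NC(=O)N[C@@H](C)c2ccccc2)c1`, 94%
compound 2, `C[C@@H](NC(=O)Nc1cccc(C(F)(F)F)c1)c1ccccc1`, 72%

In an ADME assay on the whole organism with Oryza sativa as the target, tested at 1 uM (a lower number here means a stronger effect, a higher number a weaker effect of the compound at the concentration tested), compound 1 gives 94%. In this assay compound 2 gives 72%, the lowest of the two numbers, and the gap to compound 1 lies beyond the scatter. Compound 3, `C[C@H](NC(=O)Nc1cccc(C(F)(F)F)c1)c1ccccc1`, has not yet been measured. Its change from compound 2 is the two compounds have the same atoms and bonds and differ only in configuration as drawn: 1 of 1 stereo elements differ; a stereocentre at a saturated chain carbon is drawn R in compound 2 and S in compound 3. Going by these compounds, no comparison of two measured compounds describes such a change in this assay, so the size of the step from compound 2 to compound 3 is unknown; the value of compound 2 is the only anchor, and no step beyond the scatter is assumed in either direction. Compound 3 is therefore expected to give about 76% in this assay, within 55% to 97%. The expected step of a number 4 percentage points higher from compound 2 to compound 3 (within the scatter) is held to be small, with a broad range that allows for a real difference in either direction.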

Compound 3, a percentage reported as activity, at one concentration (the size of the read-out at that concentration, not a potency): 93%
Compound 3: the middle estimate sits 17 percentage points below what was measured; the measured number falls inside the stated range.
By their numbers in this assay, from the lowest: compound 2; then compounds 3 and 1 (each within the scatter of the next).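

In this assay the stereocentre at the saturated chain carbon turns out to matter, since redrawing it from R to S gives a number 21 percentage points higher from compound 2 to compound 3 (beyond the scatter). Among the compounds drawn S, trifluoromethyl in place of ethyl on an aromatic carbon gives a number 1 percentage points lower from compound 1 to compound 3 (within the scatter), so this swap shows no step of its own in that configuration. The step between the two trifluoromethyl compounds can be assigned to configuration alone because nothing else separates them: the fact that compounds 2 and 3 differ only in the configuration as drawn

The compounds shown leave open whether the ethyl compounds would show a similar step between S and R. They also leave open how a carboxylic acid or an amine in place of trifluoromethyl on that aromatic carbon would read in this assay under either configuration.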